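Carbamate to urea: a morpholine amide on the piperidine

The compounds below may be only part of what the source reports. "The series", "measured", "known", "first", "only" and "open" are said of these compounds alone.

Compound 1 `CCCS(=O)(=O)N1CCN(c2ccc(OCC3CCN(C(=O)OC(C)C)CC3)cn2)CC1`: 300 nM
Compound 2 `CC(C)OC(=O)N1CCC(COc2ccc(N3CCN(S(=O)(=O)C4CCCCC4)CC3)nc2)CC1`: 200 nM

In a functional assay on CHO-K1 cells for agonist activity at Glucose-dependent insulinotropic receptor (Homo sapiens), read by a luciferase reporter, with a stated time of 5 h (on this read-out higher numbers stand for an effect only at larger amounts of compound and lower numbers for an effect already at smaller amounts), compound 1 gives 300 nM, the highest of the two numbers; the nearest is compound 2, reached by a 1.5-fold lower number from compound 1 to compound 2 (0.18 log units; within the scatter), a change at the sulfonyl sulfur, not at the carbamate.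

Compound 3 `CCCS(=O)(=O)N1CCN(c2ccc(OCC3CCN(C(=O)N4CCOCC4)CC3)cn2)CC1` differs from compound 1 elsewhere: morpholin-4-yl in place of isopropoxy on a carbonyl carbon. Within the data shown here, no measured step touches this carbonyl, so the one step on record, between compound 1 and compound 2, does not bear on it and the change has to be judged without a comparable pair. With nothing to say otherwise, compound 3 is expected to stay close to compound 1, with a 1.2-fold higher number from compound 1 to compound 3 (0.07 log units; within the scatter) as the estimated step, and no movement beyond the scatter is anticipated in either direction.

The estimate for compound 3 in this assay is 350 nM, with a range from 120 nM to 1000 nM.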

Compound 3, half-maximal effective concentration: > 10000 nM
Compound 3: only a limit was reported; the forecaster's own chance of this, stated with the estimate: 5%; middle value at least 28-fold (1.45 log units) away from the limit.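

Among these compounds, until now the only step on record lay at the sulfonyl sulfur, and it stayed within the scatter; the change on the carbonyl carbon does not, for in this assay morpholin-4-yl in place of isopropoxy gives an at least 33-fold higher number from compound 1 to compound 3 (1.52 log units; beyond the scatter). The result for compound 3 is a limit of the assay and not a number: the limit of > 10000 nM in this assay, at which 1 of the 3 values shown sits. The leaving and entering groups have the same counts of hydrogen-bond donors and acceptors and no net charge, so these counts do not separate them, whereas the entering group has more heavy atoms and a ring.

The compounds shown leave open whether the ring, its oxygen or the entering nitrogen goes with this step. A dimethylamino, a piperidin-1-yl or a tert-butoxy group on the same carbonyl carbon would tell these apart.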